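A styryl arm in place of the chlorophenyl

The source may hold more compounds than are shown below. What is called first, only, known or untested is meant among the compounds shown, and "the series" means these compounds.

Compound 2 `Cc1cc(O)c(C2=NN(c3ccc(S(N)(=O)=O)cc3)C(c3ccccc3Cl)C2)cc1Cl` gives 2970 nM in a functional assay on SR cells (Homo sapiens) for antiproliferative activity, with a stated time of 48 h; a lower number here means a stronger inhibitor of growth, a higher number a weaker inhibitor of growth; compound 1 `Cc1cc(O)c(C2=NN(c3ccc(S(N)(=O)=O)cc3)C(c3ccccc3O)C2)cc1Cl` gives 2220 nM in this assay. Among the measured compounds shown here, the step of a 1.3-fold higher number from compound 1 to compound 2 (0.13 log units; within the scatter) lies within the scatter, so compound 2 stands level with its only neighbour. Compound 3 `Cc1cc(O)c(C2=NN(c3ccc(S(N)(=O)=O)cc3)C(/C=C/c3ccccc3)C2)cc1Cl` differs from compound 2 by 2-phenylethenyl in place of 2-chlorophenyl on a saturated ring carbon. For the measured compounds named here, the single measured step, an exchange of hydroxy for chloro on an aromatic carbon, is a smaller change than this one and gives no direct guide, so no step beyond the scatter is expected in this assay. For compound 3 the estimate is 3000 nM, with a range of 1000 nM to 9000 nM, an expected step of a 1.0-fold higher number from compound 2 to compound 3 (0.00 log units; within the scatter).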

Compound 3, concentration for 50% growth inhibition: 12700 nM
The estimate for compound 3 lay 4.2-fold (0.63 log units) below the measured number; measured number outside the range, above it.
By their numbers in this assay, from the lowest: compounds 1 and 2 (each within the scatter of the next); then compound 3.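

On the saturated ring carbon, the 2-chlorophenyl and 2-hydroxyphenyl groups gave numbers within the scatter of each other, but 2-phenylethenyl moves the number beyond the scatter in this assay (a 4.3-fold higher number from compound 2 to compound 3 (0.63 log units; beyond the scatter); a 5.7-fold higher number from compound 1 to compound 3 (0.76 log units; beyond the scatter)). The position therefore does not accept every group carrying an aromatic ring equally, and growth inhibition weakens with this arm against both earlier compounds. Nothing available explains this weakening.

Going by these compounds, it remains open whether the weakening goes with the double bond of the arm or with the arm as a whole. A saturated 2-phenylethyl group or an unsubstituted phenyl at this carbon would help separate the two.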